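From phenyl to 3,4-difluorophenyl in compound 2

A few compounds are considered here, and "the series" means these few. Any claim that something is new, unique, unknown or untested is made for them only; others in the source may bear on it.

Compound 1 `O=c1ccc(-c2cc(C[C@]3(O)CC[C@@H](Cc4ccccc4)CC3)no2)c[nH]1`: 53.1%
Compound 2 `O[C@]1(Cc2cc(-c3cn[nH]c3)on2)CC[C@H](Cc2ccccc2)CC1`: 46.3%

Both numbers come from an ADME assay on the whole organism (strain Sprague-Dawley) for pharmacokinetics, with Rattus norvegicus as the target, using cassette dosing, at a dose of 1 mg/kg by the oral route (a lower number here means that a smaller share of the oral dose reaches the circulation, a higher number that a larger share of the oral dose reaches the circulation), and they lie within the usual scatter of each other, so compound 2 cannot be ranked against compound 1. Compound 3 `O[C@]1(Cc2cc(-c3cn[nH]c3)on2)CC[C@H](Cc2ccc(F)c(F)c2)CC1` keeps the core of compound 2 and changes one group (3,4-difluorophenyl in place of phenyl on a saturated chain carbon bound to a saturated ring carbon): 3,4-difluorophenyl in place of phenyl on a saturated chain carbon bound to a saturated ring carbon. For the measured compounds named here, the only measured step is a number 6.8 percentage points lower from compound 1 to compound 2 (within the scatter) and it concerns a different group, on an aromatic carbon. Going by the values given here, it therefore offers only indirect guidance, and no measurement yet covers a change to the phenyl. No shift beyond the scatter is expected, and the estimated step is a number 1.3 percentage points lower from compound 2 to compound 3 (within the scatter) in this assay for now. The value expected for compound 3 is 45% with an estimated range from 25% to 65% around it.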

Compound 3, oral bioavailability: 67.5%
For compound 3 the middle estimate is 22.5 percentage points below the measured one; measured number above the stated range.
By their numbers in this assay, from the lowest: compounds 2 and 1 (each within the scatter of the next); then compound 3.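

In this assay, putting 3,4-difluorophenyl in place of phenyl on a saturated chain carbon bound to a saturated ring carbon gives a number 21.2 percentage points higher from compound 2 to compound 3 (beyond the scatter). This shows that the group at this place can move the read-out by more than the usual scatter, whereas the earlier change at a different place, a number 6.8 percentage points lower from compound 1 to compound 2 (within the scatter), did not. Nothing measured here gives a reason for this step.

Only one replacement for phenyl at this place is shown, so it stays open whether a single fluorine, a chlorine or a methoxy group on the phenyl would give a similar step. As far as these compounds go, it also stays open whether the two fluorines would have the same effect on the core of compound 1, which carries a different group on an aromatic carbon.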